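A few compounds are considered here, and "the series" means these few. Any claim that something is new, unique, unknown or untested is made for them only; others in the source may bear on it.

Measured so far: compound 1 `COc1cc(/C=C2\CN(C)C/C(=C\c3ccc(Br)cc3)C2=O)cc(OC)c1`, 4270 nM; compound 2 `COc1cc(/C=C2\CN(C)C/C(=C\c3cc(OC)c(OC)c(OC)c3)C2=O)cc(OC)c1`, 720 nM.

In a functional assay on THP-1 cells (Homo sapiens) for cytotoxicity, read by MTT assay, with a stated time of 24 h (on this read-out higher numbers stand for weaker inhibition and lower numbers for stronger inhibition), compound 2 gives 720 nM, the lowest of the two numbers, while compound 1 gives 4270 nM, a higher number beyond the scatter. Among the measured compounds shown here, no single-change step joins these two. Compound 3 `COc1cc(/C=C2\CN(C)C/C(=C\c3ccc(Br)cc3)C2=O)cc(OC)c1OC` is not yet measured and differs from compound 2 by 4-bromophenyl in place of 3,5-dimethoxyphenyl on a double-bonded chain carbon bound to a double-bonded ring carbon. Nothing measured isolates this change. Because compound 1 gives 4270 nM in this assay, compound 3 is expected to fall between the two, with a step of a 2.2-fold higher number from compound 2 to compound 3 (0.35 log units; beyond the scatter) toward weaker inhibition. Compound 3 is estimated at 1600 nM, within 500 nM to 5000 nM.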

Compound 3, half-maximal inhibitory concentration: 5330 nM
Beside the measured number, compound 3's estimate is 3.3-fold (0.52 log units) below it, outside the stated range (above it).
By their numbers in this assay, from the lowest: compound 2; then compounds 1 and 3 (each within the scatter of the next).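

In this assay, among the compounds shown here, 4-bromophenyl in place of 3,5-dimethoxyphenyl on a double-bonded chain carbon bound to a double-bonded ring carbon gives weaker inhibition (a 7.4-fold higher number from compound 2 to compound 3 (0.87 log units; beyond the scatter)), the first single-change reading of this place. By contrast, methoxy in place of hydrogen on an aromatic carbon leaves the number within the scatter (a 1.2-fold higher number from compound 1 to compound 3 (0.10 log units; within the scatter)). Nothing available explains the size of either step. The compounds shown leave open how an amine or a carboxylic acid on the ring at that same place would read.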